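Working notes: replacing the 3-methoxyphenyl group of compound 2

The compounds below may be only part of what the source reports. "The series", "measured", "known", "first", "only" and "open" are said of these compounds alone.

Of the compounds shown here, two sharing one core have been measured in a functional assay on ECa-109 cells (Homo sapiens) for cytotoxicity, read by MTT assay, with a stated time of 72 h; a lower number here means a stronger inhibitor, a higher number a weaker inhibitor. Compound 1 `CN(C)c1ccc(C=C2C(=O)N(c3ccc(Cl)cc3)N(c3ccc(Cl)cc3)C2=O)cc1` gives > 128000 nM, which is a limit of the assay and not a number. Among the measured compounds shown here, compound 2 `COc1cccc(C=C2C(=O)N(c3ccc(Cl)cc3)N(c3ccc(Cl)cc3)C2=O)c1` gives 29000 nM, the only actual number so far. Compound 3 `O=C1C(=Cc2ccc(Cl)cc2Cl)C(=O)N(c2ccc(Cl)cc2)N1c1ccc(Cl)cc1` is the next to be read, and it differs from compound 2 as follows: 2,4-dichlorophenyl in place of 3-methoxyphenyl on a double-bonded chain carbon bound to a double-bonded ring carbon.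

For the measured compounds named here, one measured step bears on this change, since it falls at the same place, on a double-bonded chain carbon bound to a double-bonded ring carbon. That step is an at least 4.4-fold lower number from compound 1 to compound 2 (0.64 log units; beyond the scatter). It gives a bound and not a size because of the limit of > 128000 nM in this assay, at which 1 of the 2 values shown sits. It shows that the number can move with the group at this place, but it gives no direction for a 2,4-dichlorophenyl group. No step beyond the scatter is therefore expected, though with wide uncertainty in either direction. The expected outcome in this assay is a 1.2-fold lower number from compound 2 to compound 3 (0.08 log units; within the scatter). For compound 3 the estimated value is 24000 nM, with an expected range of 7000 nM to 80000 nM.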

Compound 3, half-maximal inhibitory concentration: 60200 nM
Compound 3: middle estimate off by 2.5-fold (0.40 log units), on the low side, within the range that was stated.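

Among the compounds shown here, the place on a double-bonded chain carbon bound to a double-bonded ring carbon now gives a first sized step between two actual numbers in this assay: with 2,4-dichlorophenyl in place of 3-methoxyphenyl, the result is a 2.1-fold higher number from compound 2 to compound 3 (0.32 log units; beyond the scatter). The earlier step gave only a bound, whereas this one shows that the number also responds when one substituted phenyl group replaces another, and compound 2 now holds the lowest number of the three. Against the 4-(dimethylamino)phenyl group, the 2,4-dichlorophenyl group gives an at least 2.1-fold lower number from compound 1 to compound 3 (0.32 log units; beyond the scatter), and this remains a bound and not a size because of the following: the limit of > 128000 nM in this assay, at which 1 of the 3 values shown sits.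

The single step changes both the kind and the number of substituents on the phenyl ring, so the compounds shown cannot separate the contribution of the methoxy group from that of either chlorine, and an unsubstituted phenyl or a phenyl carrying one chlorine would be needed to do so. All three compounds carry a substituted phenyl group at this place, which leaves open how a carboxylic acid, a hydroxyl or a pyridine ring would read here.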